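The source may report more compounds than this note shows. Statements on the series, on what has been measured and on what is new or still open speak of the compounds shown alone.

Measured compounds:
compound 1, `CC(C)[C@H](NC(=O)OCc1ccccc1)C(=O)N[C@@H](CO)C(=O)N[C@@H](CCCNC(=N)N)C(=O)CF`, 290 nM
compound 2, `CC(C)[C@H](NC(=O)OCc1ccccc1)C(=O)N1CCCC[C@H]1C(=O)N[C@@H](CCCNC(=N)N)C(=O)CF`, 730 nM
compound 3, `CC(C)[C@H](NC(=O)c1ccc(Br)cc1)C(=O)N[C@@H](CO)C(=O)N[C@@H](CCCNC(=N)N)C(=O)CF`, 150 nM

All three were tested in a functional assay on OCI-Ly3 cells (Homo sapiens) for inhibition, read by CellTiter-Glo, with stated times of 48 h and 96 h; a higher number here means a weaker inhibitor of growth, a lower number a stronger inhibitor of growth. Compound 3 differs from compound 1 by 4-bromophenyl in place of benzyloxy on a carbonyl carbon, and that change gave a 1.9-fold lower number from compound 1 to compound 3 (0.29 log units; within the scatter). Compound 2 shares the benzyloxycarbonyl end of compound 1 but has a different core; how the two cores differ is not broken down here. Among the three, compound 2 has the highest number, beyond the scatter from both compound 1 and compound 3.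

Compound 4, `CC(C)[C@H](NC(=O)c1ccc(Br)cc1)C(=O)N1CCCC[C@H]1C(=O)N[C@@H](CCCNC(=N)N)C(=O)CF`, is not yet measured. It differs from compound 2 by 4-bromophenyl in place of benzyloxy on a carbonyl carbon, the same change that turns compound 1 into compound 3, made at the same place. Resting on the step seen there, a 1.9-fold lower number from compound 1 to compound 3 (0.29 log units; within the scatter), compound 4 is expected to move from compound 2 by about a 1.9-fold lower number from compound 2 to compound 4 (0.27 log units; within the scatter) in this assay, a shift that itself stays within the scatter. The estimate for compound 4 in this assay is therefore 390 nM, with a plausible range from 180 nM to 850 nM.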

Compound 4, concentration for 50% growth inhibition: 460 nM
Compound 4: the middle estimate sits 1.2-fold (0.07 log units) below what was measured, and the stated range covers the measured number.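

In this assay the change from benzyloxy to 4-bromophenyl on the carbonyl carbon gives a 1.6-fold lower number from compound 2 to compound 4 (0.20 log units; within the scatter) and so reads much as it did on the core of compound 1: the same change on two cores in this assay, a 1.9-fold lower number (0.29 log units; within the scatter) from compound 1 to compound 3 and a 1.6-fold lower number (0.20 log units; within the scatter) from compound 2 to compound 4, 1.2-fold (0.09 log units) apart, within the scatter of two such steps. On these two cores, then, the change carries over with no difference in size that can be told from the scatter. Each step on its own also lies within the scatter, however, so this shows neither a firm effect of the change on either core nor that it would carry over to any third core in the series.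

The compounds shown leave open whether other groups on this carbonyl carbon, such as a plain phenyl, a 4-chlorophenyl or an alkyl chain, would give steps that also match on both cores. They also leave open how a group such as an amine or a carboxylic acid on that phenyl ring would behave.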